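A Third Methoxy Group: From Compound 3 to Compound 4

The compounds below may be only part of what the source reports. "The series", "measured", "known", "first", "only" and "open" are said of these compounds alone.

Of the compounds shown here, three that share one core have been tested in a functional assay on U-251 cells (Homo sapiens) for inhibition, read by sulforhodamine B assay, with a stated time of 48 h; on this read-out lower numbers stand for higher toxicity in this test and higher numbers for lower toxicity in this test. Compound 1 `COc1cc(-c2cc(/C=C/C(=O)c3ccc(N)cc3)[nH]n2)cc(OC)c1OC` gives 5390 nM in this assay. Compound 2 `COc1cc(-c2cc(/C=C/C(=O)c3ccc(Cl)c(Cl)c3)[nH]n2)cc(OC)c1OC` reaches only a limit of this assay, reported as > 100000 nM, so for it no number is known. Compound 3 `COc1ccc(-c2cc(/C=C/C(=O)c3cc(OC)c(OC)c(OC)c3)[nH]n2)cc1OC` gives 5130 nM in this assay; among the two numbers it stands at the lowest, and compound 1 sits nearest to it at a gap within the scatter, so the two cannot be told apart.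

Compound 4 `COc1cc(C(=O)/C=C/c2cc(-c3cc(OC)c(OC)c(OC)c3)n[nH]2)cc(OC)c1OC` differs from compound 3 in one place: methoxy in place of hydrogen on an aromatic carbon. Going by the values given here, the only measured step, an at least 18-fold higher number from compound 1 to compound 2 (1.26 log units; beyond the scatter), alters the ring on the carbonyl carbon, not the ring changed here, so it offers no direct guide, and no measured pair varies this ring at all. With nothing pointing one way or the other, the expected step is one that stays within the scatter, a 1.0-fold lower number from compound 3 to compound 4 (0.01 log units; within the scatter). Compound 4 is therefore estimated to give 5000 nM in this assay, with a likely range from 1500 nM to 16000 nM.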

Compound 4, concentration lethal to 50% of the cells: 5670 nM
For compound 4 the middle estimate is 1.1-fold (0.05 log units) below the measured one, and the stated range covers the measured number.
By their numbers in this assay, from the lowest: compounds 3, 1 and 4 (each within the scatter of the next). At a limit, above all of these: compound 2.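

Going by these compounds alone, this is the first measured step on this ring, and in this assay it reads a 1.1-fold higher number from compound 3 to compound 4 (0.04 log units; within the scatter). Compound 3 and compound 4 therefore cannot be told apart, so in this test a methoxy group can take the place of hydrogen at this aromatic carbon, ortho to a methoxy group, without a shift that can be distinguished from the scatter. Within the data shown here, the only other step, an at least 18-fold higher number from compound 1 to compound 2 (1.26 log units; beyond the scatter), falls on the ring at the carbonyl carbon and lies beyond the scatter, but nothing in the data explains why these two changes differ or why this new one leaves the number within the scatter.

At this carbon the compounds shown carry only hydrogen or methoxy, so it remains open whether an ethoxy group, a hydroxyl group or an amine would also stay within the scatter. As far as these compounds go, the swap is also seen against only one partner, a trimethoxyphenyl ring on the carbonyl carbon, so its result with a 4-aminophenyl or 3,4-dichlorophenyl ring there remains unknown.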